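A chlorophenyl swap on the carbonyl of compound 3

A few compounds are considered here, and "the series" means these few. Any claim that something is new, unique, unknown or untested is made for them only; others in the source may bear on it.

Four compounds share one core and differ only in the group on a carbonyl carbon. In a functional assay on MCF7 cells (Homo sapiens) for antiproliferative activity, read by MTT assay, with a stated time of 72 h (a lower number here means a stronger inhibitor, a higher number a weaker inhibitor), compound 3 (`CC1=CC[C@H]2[C@H](CC[C@]2(C)O)C(C)(C)[C@@H]1CC[C@H]1[C@]2(C)CC[C@H](OC(=O)c3cccc([N+](=O)[O-])c3)C(C)(C)O[C@H]2CC[C@@]1(C)O`) gives 36000 nM and compound 2 (`CC1=CC[C@H]2[C@H](CC[C@]2(C)O)C(C)(C)[C@@H]1CC[C@H]1[C@]2(C)CC[C@H](OC(=O)c3ccc(Cl)cc3)C(C)(C)O[C@H]2CC[C@@]1(C)O`) gives 24100 nM as its value. These two sit together, with a 1.5-fold higher number from compound 2 to compound 3 (0.17 log units; within the scatter) separating them. Compound 1 (`CC1=CC[C@H]2[C@H](CC[C@]2(C)O)C(C)(C)[C@@H]1CC[C@H]1[C@]2(C)CC[C@H](OC(=O)CCC(=O)O)C(C)(C)O[C@H]2CC[C@@]1(C)O`) reaches only a limit of the assay (> 50000 nM), not a true number.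

Compound 4 (`CC1=CC[C@H]2[C@H](CC[C@]2(C)O)C(C)(C)[C@@H]1CC[C@H]1[C@]2(C)CC[C@H](OC(=O)c3ccccc3Cl)C(C)(C)O[C@H]2CC[C@@]1(C)O`) has 2-chlorophenyl in place of 3-nitrophenyl on a carbonyl carbon. Going by the values given here, the best guide is the one measured exchange between two such aromatic groups, which is small (a 1.5-fold higher number from compound 2 to compound 3 (0.17 log units; within the scatter)). The steps that start from the limit, an at least 2.0-fold lower number from compound 1 to compound 2 (0.31 log units; beyond the scatter) and an at least 1.3-fold lower number from compound 1 to compound 3 (0.14 log units; that floor lies within the scatter), give only floors and concern a different kind of group. A chlorophenyl group also sits in compound 2, at 24100 nM in this assay, so no change beyond the scatter is expected. The expected step is small (a 1.2-fold lower number from compound 3 to compound 4 (0.08 log units; within the scatter)). The estimated value for compound 4 is 30000 nM in a range from 15000 nM to 50000 nM as the likely span.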

Compound 4, half-maximal inhibitory concentration: 12100 nM
The estimate for compound 4 lay 2.5-fold (0.39 log units) above the measured number; measured number below the stated range.
By their numbers in this assay, from the lowest: compounds 4, 2 and 3 (each within the scatter of the next, the first and the last beyond it). At a limit, above all of these: compound 1.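

Going by these compounds alone, the result shows that a swap between two aromatic groups on this carbonyl carbon can move the number beyond the scatter in this assay: a 3.0-fold lower number from compound 3 to compound 4 (0.47 log units; beyond the scatter), whereas the one such exchange seen earlier stayed within it. Moving the chlorine, from 4-chlorophenyl to 2-chlorophenyl, gives a 2.0-fold lower number from compound 2 to compound 4 (0.30 log units; within the scatter), which is still within the scatter, so the place of the chlorine on the ring cannot yet be said to matter. Against the succinate-like chain ending in a carboxylic acid, the step is an at least 4.1-fold lower number from compound 1 to compound 4 (0.61 log units; beyond the scatter), the largest of the floors so far, and it remains a floor: the limit of > 50000 nM in this assay, at which 1 of the 4 values shown sits.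

Since nitro and chlorine differ in both identity and ring place between compound 3 and compound 4, these compounds cannot separate the two changes. A 3-chlorophenyl or 2-nitrophenyl group would address that, and a plain phenyl group would show what either ring substituent contributes.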